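Hydroxy for fluoro on the diacetate chain: compounds 1 to 4

The source may report more compounds than this note shows. Statements on the series, on what has been measured and on what is new or still open speak of the compounds shown alone.

Three compounds of the series carry the same diacetate chain and differ in the core or in one substituent on the chain. Compound 1 `COc1nc(CC(O)(COC(C)=O)COC(C)=O)c(C)c(OC)n1`, compound 2 `COc1nc(CC(F)(COC(C)=O)COC(C)=O)c(C)c(OC)n1` and compound 3 `COc1nc(=O)n(C)c(CC(F)(COC(C)=O)COC(C)=O)c1C` have been tested in a functional assay on HepG2 cells (Homo sapiens) for antiproliferative activity, read by MTT assay, with a stated time of 72 h; a higher number here means a weaker inhibitor, a lower number a stronger inhibitor. In this assay compound 1 reaches only the limit of the assay, > 100000 nM. Compound 2 likewise shows only the limit, > 100000 nM. Compound 3 also stands at the limit, > 100000 nM.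

The change from compound 2 to compound 1 is hydroxy in place of fluoro on a saturated chain carbon bound to three saturated chain carbons. Its step is a step that the two limits leave unreadable from compound 2 to compound 1, since both values sit at the limit of > 100000 nM in this assay, at which 3 of the 3 values shown sit.

Compound 3 and compound 2 are built from the same atoms joined differently; the difference between the two cores is not broken down here. Among the compounds with values here, compound 4 `COc1nc(=O)n(C)c(CC(O)(COC(C)=O)COC(C)=O)c1C`, not yet measured, differs from compound 3 by hydroxy in place of fluoro on a saturated chain carbon bound to three saturated chain carbons, which is the same change as the one from compound 2 to compound 1, at the same place.

Within the data shown here, because every value so far sits at the limit of > 100000 nM in this assay, at which 3 of the 3 values shown sit, the same change on the core of compound 3 is expected to leave compound 4 at the limit as well, so the expected step is a step that the limit leaves unreadable from compound 3 to compound 4. The estimate for compound 4 in this assay is 200000 nM, with an expected range from 50000 nM to 1000000 nM.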

Compound 4, half-maximal inhibitory concentration: > 100000 nM
Compound 4 ended at the assay's limit; the forecaster's own chance of this, stated with the estimate: 90%; the middle value is on the limit's open side.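

In this assay compound 4 gives > 100000 nM, which is a limit of the assay. No new step can be read between compound 3 and compound 4, as both values are limits: the limit of > 100000 nM in this assay, at which 4 of the 4 values shown sit.

The compounds shown leave open whether hydroxy in place of fluoro changes antiproliferative activity on either core, and how compounds 1 to 4 would rank against one another.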